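A few compounds are considered here, and "the series" means these few. Any claim that something is new, unique, unknown or untested is made for them only; others in the source may bear on it.

Compound 1 `COc1ccc(-c2ccc3c(NCCCNCc4cccc(OC)c4O)ccnc3c2)cc1` is measured in a physicochemical assay for solubility, with a stated time of 18 h, at pH 7.4 (on this read-out higher numbers stand for higher solubility and lower numbers for lower solubility), at 32000 nM. Compound 2 `COc1cccc(CNCCCNc2ccnc3cc(-c4ccc(C(C)(C)C)cc4)ccc23)c1O` gives 32000 nM in this assay, and compound 3 `COc1cccc(CNCCCNc2ccnc3cc(CCC(C)C)ccc23)c1O` gives 4200 nM. Compound 1 therefore stands level with compound 2, the two together forming the top of the three, while compound 3 sits furthest from it: the step of no change at the digits printed from compound 1 to compound 2 (within the scatter) is within the scatter, whereas a 7.6-fold lower number from compound 1 to compound 3 (0.88 log units; beyond the scatter) and a 7.6-fold lower number from compound 2 to compound 3 (0.88 log units; beyond the scatter) are both beyond it.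

Compound 4 `COc1ccc(-c2ccc3c(NCCCNCc4ccco4)ccnc3c2)cc1` is not yet measured. Compared with compound 1 the change is furan-2-yl in place of 2-hydroxy-3-methoxyphenyl on a saturated chain carbon bound to an amine nitrogen. Within the data shown here, none of the measured steps touches this part of the molecule; all three concern the group on the aromatic carbon of the shared core, so they give no direct guide to the present change. Among the measured compounds shown here, with no relevant precedent, compound 4 is expected to stay close to compound 1 in this assay, the step of a 1.3-fold lower number from compound 1 to compound 4 (0.11 log units; within the scatter) being the estimate. The value estimated for compound 4 is 25000 nM, with a range from 8000 nM to 80000 nM.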

Compound 4, solubility: 32000 nM
The estimate for compound 4 lay 1.3-fold (0.11 log units) below the measured number; measured number inside the range.
By their numbers in this assay, from the lowest: compound 3; then compounds 1, 2 and 4 (each within the scatter of the next).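

This is the first change shown on a saturated chain carbon bound to an amine nitrogen, and in this assay furan-2-yl in place of 2-hydroxy-3-methoxyphenyl leaves the read-out flat (no change at the digits printed from compound 1 to compound 4 (within the scatter)). The number therefore holds while 9 heavy atoms with 1 hydrogen-bond donor give way to 5 heavy atoms with none, whereas isopentyl on an aromatic carbon of the shared core did shift it (a 7.6-fold lower number from compound 1 to compound 3 (0.88 log units; beyond the scatter)). Nothing measured here explains why this step is flat.

On these data alone, whether furan-2-yl behaves the same way with the isopentyl group of compound 3 on the core remains open. So does the outcome of placing a carboxylic acid, a piperidine or a longer alkyl chain on this saturated chain carbon.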